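This account rests on a few compounds, and the source may have more. Where it says the series, first, only, none or still open, it means among the compounds named here.

In an ADME assay on microsomes from liver (Mus musculus) for metabolic stability, read by LC-MS, with a stated time of 30 min, tested at 1 uM (on this read-out lower numbers stand for a less stable compound and higher numbers for a more stable compound), compound 1 `O=C(NCc1ccc(S(=O)(=O)c2cccc(F)c2)cc1)c1cc2cnccc2[nH]1` gives 44%. Compound 2 `O=C(NCc1ccc(S(=O)(=O)c2ccccc2)cc1)c1cc(-c2cccnc2)[nH]n1` gives 42%, which lies within the usual scatter of compound 1. Compound 3 `O=C(NCc1ccc(S(=O)(=O)c2ccccc2)cc1)c1cn2ccnc2cn1` gives 13%, lower than compound 1 by a gap beyond the scatter. Compound 4 `O=C(NCc1ccc(S(=O)(=O)c2ccc(F)cc2)cc1)c1cc2cnccc2[nH]1` is not yet measured and has the same atoms as compound 1, joined differently: 4-fluorophenyl in place of 3-fluorophenyl on a sulfonyl sulfur. The change is 4-fluorophenyl in place of 3-fluorophenyl on a sulfonyl sulfur. For the measured compounds named here, no measured pair isolates a single change, so the data offer no direct precedent, and no step beyond the scatter is expected in this assay. The estimated step of a number 1 percentage points higher from compound 1 to compound 4 (within the scatter) is expected to stay within the scatter. Compound 4 is expected at 45%, with an estimated range of 27% to 63%.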

Compound 4, percent of the compound remaining: 72%
For compound 4 the middle estimate is 27 percentage points below the measured one; measured number above the stated range.
By their numbers in this assay, from the lowest: compound 3; then compounds 2 and 1 (each within the scatter of the next); then compound 4.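

In this assay, for the compounds shown here, the first comparison that isolates one change gives a number 28 percentage points higher from compound 1 to compound 4 (beyond the scatter). Moving the fluorine on the ring carried by the sulfonyl sulfur, with no atom gained or lost, is therefore enough to shift this read-out, so this position is sensitive to the placement of a substituent. No available measurement explains the step.

Open, as far as these compounds go, is whether an unsubstituted phenyl on the core of compound 1 would fall with compound 1 or compound 4. Also open, from the compounds shown here alone, is whether chlorine or a methoxy group would follow the fluorine pattern.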